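The source may hold more compounds than are shown below. What is called first, only, known or untested is meant among the compounds shown, and "the series" means these compounds.

Measured compounds:
- compound 1 `COc1ccc(-c2ccc3c(NCCCNCc4cccc(OC)c4O)ccnc3c2)cc1` gives 1600 nM
- compound 2 `COc1cccc(CNCCCNc2ccnc3cc(Cc4ccc(F)cc4)ccc23)c1O` gives 4780 nM

In an ADME assay on HepG2 cells (Homo sapiens) for cytotoxicity, read by luminescence, CellTiter-Glo and ATP content, with a stated time of 72 h (on this read-out higher numbers stand for an effect only at larger amounts of compound and lower numbers for an effect already at smaller amounts), compound 2 stands at the highest of the two numbers; its nearest neighbour is compound 1, and the difference between them is a 3.0-fold higher number from compound 1 to compound 2 (0.48 log units; beyond the scatter), a step that came with 4-fluorobenzyl in place of 4-methoxyphenyl on an aromatic carbon.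

Compound 3 `COc1ccc(Oc2ccc3c(NCCCNCc4cccc(OC)c4O)ccnc3c2)cc1` is not yet measured. It differs from compound 2 in one place: 4-methoxyphenoxy in place of 4-fluorobenzyl on an aromatic carbon. This change returns a methoxy-bearing ring to that position, now joined through an oxygen, so it partly undoes the move from compound 1 to compound 2. Within the data shown here, the only step that bears on it is a 3.0-fold higher number from compound 1 to compound 2 (0.48 log units; beyond the scatter), which was modest. Going by these compounds, a step of similar size in the opposite direction is therefore expected in this assay, taking compound 3 back toward compound 1, though the oxygen linker is untested here.

Compound 3 is expected to give 2200 nM, estimated between 900 nM and 6000 nM, which means an expected step of a 2.2-fold lower number from compound 2 to compound 3 (0.34 log units; beyond the scatter).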

Compound 3, half-maximal effective concentration: 5500 nM
Estimate against measurement, compound 3: 2.5-fold (0.40 log units) below; measured number inside the range.
By their numbers in this assay, from the lowest: compound 1; then compounds 2 and 3 (each within the scatter of the next).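

In this assay, joining the methoxy-bearing ring through an oxygen does not take the number back toward compound 1: there is a 1.2-fold higher number from compound 2 to compound 3 (0.06 log units; within the scatter), so 4-methoxyphenoxy and 4-fluorobenzyl cannot be told apart at this position. Inserting the oxygen into the 4-methoxyphenyl group gives a 3.4-fold higher number from compound 1 to compound 3 (0.54 log units; beyond the scatter), which shows that the methoxy-bearing ring alone does not set the number and that its connection to the core matters among these compounds. No measurement shown gives a cause for this difference.

Going by these compounds, it remains open whether the lower number of compound 1 goes with the directly attached ring or with its methoxy group, and a 4-fluorophenyl group at this position would separate the two. Also open, on these data alone, is how a group without an aromatic ring, such as an amine or a carboxylic acid, would read here.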